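Taking the carboxy group off compound 2

This account rests on a few compounds, and the source may have more. Where it says the series, first, only, none or still open, it means among the compounds named here.

In a functional assay on HT-1080 cells (Homo sapiens) for antiproliferative activity, read by MTT assay, with a stated time of 72 h (a lower number here means a stronger inhibitor, a higher number a weaker inhibitor), compound 2 (`COc1ccc(-c2cc(C(=O)O)sc2-c2cc(OC)c(OC)c(OC)c2)cc1`) reads 5810 nM and cannot be told apart from compound 1 (`CCOC(=O)c1cc(-c2ccc(OC)cc2)c(-c2cc(OC)c(OC)c(OC)c2)s1`), which reads 7630 nM and carries ethyl in place of the acid hydrogen. The step between them is small (a 1.3-fold lower number from compound 1 to compound 2 (0.12 log units; within the scatter)). Compound 3 (`COc1ccc(-c2cc(C(=O)O)sc2-c2cc(OC)c(OC)c(OC)c2)cc1[N+](=O)[O-]`) has nitro in place of hydrogen on an aromatic carbon, reads 38100 nM and stands clearly apart (a 6.6-fold higher number from compound 2 to compound 3 (0.82 log units; beyond the scatter)).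

The next structure, compound 4 (`COc1ccc(-c2ccsc2-c2cc(OC)c(OC)c(OC)c2)cc1`), has hydrogen in place of carboxy on an aromatic carbon. For the measured compounds named here, no measured step removes this group outright, so the evidence is indirect. The nearest step alters the carboxy group but keeps it (a 1.3-fold lower number from compound 1 to compound 2 (0.12 log units; within the scatter)), and it stayed within the scatter. Going by the values given here, the nitro step (a 6.6-fold higher number from compound 2 to compound 3 (0.82 log units; beyond the scatter)) touches a different part of the molecule and shows only that a single change can move the number in this assay. A step within the scatter is therefore the best expectation, with only a slight and uncertain lean towards a lower number. The expected step is a 1.7-fold lower number from compound 2 to compound 4 (0.22 log units; within the scatter) and it remains a loose estimate. The estimate for compound 4 is 3500 nM with an expected range from 500 nM to 20000 nM and this range is kept wide, as the whole group leaves.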

Compound 4, half-maximal inhibitory concentration: 3620 nM
Beside the measured number, compound 4's estimate is 1.0-fold (0.01 log units) below it, within the range that was stated.
By their numbers in this assay, from the lowest: compounds 4, 2 and 1 (each within the scatter of the next, the first and the last beyond it); then compound 3.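

Earlier steps only altered the carboxy group, whereas here the whole group leaves the aromatic carbon next to the ring sulfur, and in this assay the outcome cannot be told apart from the acid (a 1.6-fold lower number from compound 2 to compound 4 (0.21 log units; within the scatter)). For this read-out, then, a carboxy group at this position is not required, and neither are the hydrogen-bond donor and acceptor that leave with it. Removing the full ethoxycarbonyl group does give a step beyond the scatter (a 2.1-fold lower number from compound 1 to compound 4 (0.32 log units; beyond the scatter)), but it is only modest, and since compound 1 and compound 2 stay within the scatter of each other, it marks a small edge rather than a real gain from emptying the position; nothing measured here explains why so large a removal changes the number so little.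

Going by these compounds, whether a different group at this carbon, such as an amine, a primary amide or a longer chain, would separate from compound 2 and compound 4 remains open. Also open, on these data alone, is whether the nitro group of compound 3 would give a similar step on the core of compound 4, which has no carboxy group.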